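Swapping the 4-(tert-butyl)phenyl arm for 2-methoxyphenoxy

A few compounds are considered here, and "the series" means these few. Any claim that something is new, unique, unknown or untested is made for them only; others in the source may bear on it.

Compound 2 `COc1ccc(F)cc1CNCCCNc1ccnc2cc(-c3ccc(C(C)(C)C)cc3)ccc12` holds the highest of the two numbers recorded in an ADME assay for permeability, using PAMPA, with a stated time of 30 min, at pH 7.4 (a lower number here means that the compound crosses the layer more slowly, a higher number that the compound crosses the layer faster), where compound 2 gives 237 10^-6 cm/s. Within the data shown here, its only neighbour is compound 1 `COc1ccc(F)cc1CNCCCNc1ccnc2cc(C3CCCCC3)ccc12`, which in this assay gives 23 10^-6 cm/s. Among the measured compounds shown here, the one measured step, a 10-fold higher number from compound 1 to compound 2 (1.01 log units; beyond the scatter), came with 4-(tert-butyl)phenyl in place of cyclohexyl on an aromatic carbon.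

Compound 3 `COc1ccc(F)cc1CNCCCNc1ccnc2cc(Oc3ccccc3OC)ccc12` is still unmeasured. Its single change from compound 2 is: 2-methoxyphenoxy in place of 4-(tert-butyl)phenyl on an aromatic carbon

For the measured compounds named here, that earlier step bears on this one only loosely, since it compared cyclohexyl with 4-(tert-butyl)phenyl, and no measured pair compares 2-methoxyphenoxy with anything. Given that the large rise of a 10-fold higher number from compound 1 to compound 2 (1.01 log units; beyond the scatter) accompanied the group that now leaves, a step downward beyond the scatter is expected, though its size is uncertain. Compound 3 is therefore expected to show a 3.4-fold lower number from compound 2 to compound 3 (0.53 log units; beyond the scatter). In this assay compound 3 is estimated at 70 10^-6 cm/s, with a likely range from 20 10^-6 cm/s to 200 10^-6 cm/s.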

Compound 3, apparent permeability: 317 10^-6 cm/s
Beside the measured number, compound 3's estimate is 4.5-fold (0.66 log units) below it; the whole stated range lies below it.
By their numbers in this assay, from the lowest: compound 1; then compounds 2 and 3 (each within the scatter of the next).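

In this assay, 2-methoxyphenoxy and 4-(tert-butyl)phenyl cannot be told apart on this aromatic carbon: the change gives a 1.3-fold higher number from compound 2 to compound 3 (0.13 log units; within the scatter). Set against cyclohexyl, the same 2-methoxyphenoxy group gives a 14-fold higher number from compound 1 to compound 3 (1.14 log units; beyond the scatter), so the large gap first seen with 4-(tert-butyl)phenyl is not unique to that group and appears again with a second, differently built substituent whose ring is joined through oxygen. Nothing measured here accounts for this result.

The compounds shown leave open whether the shared six-membered aromatic ring of carbon only is what separates compounds 2 and 3 from compound 1, and an unsubstituted phenyl or phenoxy group would bear on that. Going by these compounds, how a charged group at this position, such as an amine or a carboxylic acid, would read also remains open.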